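Oxygen for sulfur in the five-membered ring

The source may hold more compounds than are shown below. What is called first, only, known or untested is meant among the compounds shown, and "the series" means these compounds.

Measured compounds:
Compound 1 `O=C(NCc1ccccc1)Oc1ccc(C2=NCCS2)cc1`: 42000 nM
Compound 2 `Cc1ccccc1CNC(=O)Oc1ccc(C2=NCCS2)cc1`: 46000 nM
Compound 3 `COc1ccc(CNC(=O)Oc2ccc(C3=NCCS3)cc2)cc1`: 46000 nM

All three were run in an assay on cell membranes (strain Wistar) for inhibition of Monoglyceride lipase (Rattus norvegicus), read by HPLC; on this read-out lower numbers stand for stronger inhibition and higher numbers for weaker inhibition. Compound 2 stands level with compound 3 at the digits shown, the two together the highest of the three numbers; the step of a 1.1-fold higher number from compound 1 to compound 2 (0.04 log units; within the scatter) and the step of no change at the digits printed from compound 2 to compound 3 (within the scatter) are both within the scatter, so the three compounds read as one level.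

Compound 4 `Cc1ccccc1CNC(=O)Oc1ccc(C2=NCCO2)cc1` differs from compound 2 by a group of 5 heavy atoms (3 carbon, 1 nitrogen, 1 oxygen; one five-membered non-aromatic ring with 2 hetero atoms) in place of a group of 5 heavy atoms (3 carbon, 1 nitrogen, 1 sulfur; one five-membered non-aromatic ring with 2 hetero atoms), on an aromatic carbon; in words, a group of 5 heavy atoms (3 carbon, 1 nitrogen, 1 oxygen; one five-membered non-aromatic ring with 2 hetero atoms) in place of a group of 5 heavy atoms (3 carbon, 1 nitrogen, 1 sulfur; one five-membered non-aromatic ring with 2 hetero atoms), on an aromatic carbon, para to a large group.

Among the measured compounds shown here, none of the measured steps touches this ring: a 1.1-fold higher number from compound 1 to compound 2 (0.04 log units; within the scatter), a 1.1-fold higher number from compound 1 to compound 3 (0.04 log units; within the scatter) and no change at the digits printed from compound 2 to compound 3 (within the scatter) all change the other end of the molecule and all sit within the scatter. For the measured compounds named here, there is no measured precedent for the ring exchange, so the expected step of no change at the digits printed from compound 2 to compound 4 (within the scatter) is none beyond the scatter, with a wide range. For compound 4 in this assay the estimate is 46000 nM, between 15000 nM and 140000 nM.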

Compound 4, half-maximal inhibitory concentration: 35000 nM
The estimate for compound 4 lay 1.3-fold (0.12 log units) above the measured number; the range from low to high includes it.
By their numbers in this assay, from the lowest: compounds 4, 1, 2 and 3 (each within the scatter of the next).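

In this assay, among the compounds shown here, the five-membered non-aromatic ring on the aromatic carbon is changed for the first time, and the exchange of its sulfur for oxygen gives a 1.3-fold lower number from compound 2 to compound 4 (0.12 log units; within the scatter), so this position shows no measurable response to this change. Changes at the other end of the molecule and this change at the ring now all stay within the scatter, and compounds 1, 2, 3 and 4 read as one level, still in the high range of the numbers in this assay. No independent measurement on these compounds bears on this reading.

The compounds shown leave open whether this position responds to anything other than a swap of one ring atom, such as an amine or a carboxylic acid in place of the five-membered ring. They also leave open whether a longer chain at the other end of the molecule would move the number out of this level.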